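Compound 3 to compound 4: chlorophenyl exchange, working notes

The source may report more compounds than this note shows. Statements on the series, on what has been measured and on what is new or still open speak of the compounds shown alone.

The three measured compounds share one core and differ only in the aromatic group attached to it. Compound 1 `COc1nc(-c2ccsc2)ccc1[C@@H](c1ccccc1)[C@@](O)(CCN(C)C)c1cccc2ccccc12` gives, in a toxicity assay on HeLa cells (Homo sapiens) for cytotoxicity (on this read-out higher numbers stand for lower toxicity in this test and lower numbers for higher toxicity in this test), only the limit > 64 ug/mL. Compound 2 `COc1nc(-c2ccncc2)ccc1[C@@H](c1ccccc1)[C@@](O)(CCN(C)C)c1cccc2ccccc12` gives 9.6 ug/mL in this assay. Compound 3 `COc1nc(-c2ccc(Cl)c(F)c2)ccc1[C@@H](c1ccccc1)[C@@](O)(CCN(C)C)c1cccc2ccccc12` likewise gives only the limit > 64 ug/mL in this assay. Among the measured compounds shown here, compound 3 therefore stands at the limit together with compound 1, while compound 2 is the single value that is a number. The step of an at least 6.6-fold higher number from compound 2 to compound 3 (0.82 log units; beyond the scatter) is beyond the scatter, as is the step of an at least 6.6-fold lower number from compound 1 to compound 2 (0.82 log units; beyond the scatter); the step that the two limits leave unreadable from compound 1 to compound 3 cannot be read because of the limit of > 64 ug/mL in this assay, at which 2 of the 3 values shown sit.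

Compound 4 `COc1nc(-c2ccccc2Cl)ccc1[C@@H](c1ccccc1)[C@@](O)(CCN(C)C)c1cccc2ccccc12` has not yet been measured. The change is 2-chlorophenyl in place of 4-chloro-3-fluorophenyl on an aromatic carbon. For the measured compounds named here, every measured step replaces thiophen-3-yl or pyridin-4-yl; none exchanges one carbon-only six-membered ring for another, so no measured step bears directly on this change. The nearest point of reference is compound 3 itself, which sits at the limit. A step within the scatter is therefore expected, a number no higher from compound 3 to compound 4 (the limit leaves the size open). Compound 4 is expected to give about 64 ug/mL in this assay, within 25 ug/mL to 150 ug/mL, and most likely again reported only as a limit.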

Compound 4, half-maximal cytotoxic concentration: > 64 ug/mL
Compound 4 gave a limit, no number; the forecaster's own chance of this, stated with the estimate: 65%; the middle value sits exactly at the limit.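

In this assay, a second carbon-only six-membered aromatic ring on this aromatic carbon next to the ring nitrogen, 2-chlorophenyl in place of 4-chloro-3-fluorophenyl, again gives no number: compound 4 gives > 64 ug/mL, which is a limit. The exchange of pyridin-4-yl for 2-chlorophenyl gives an at least 6.6-fold higher number from compound 2 to compound 4 (0.82 log units; beyond the scatter), so the separation of compound 2 from the limit now holds against a third group, and among the four compounds the pyridin-4-yl group alone goes with a number. The steps among compound 1, compound 3 and compound 4 cannot be read because all three stop at the same limit: the limit of > 64 ug/mL in this assay, at which 3 of the 4 values shown sit.

From the compounds shown here alone, how far compound 1, compound 3 and compound 4 each lie past that limit stays open, so no order among them can be given, and the effect of the chlorine and fluorine substituents on the phenyl ring cannot be separated. Also open, going by these compounds, is whether another nitrogen-bearing group at this position, such as pyridin-3-yl or a phenyl ring carrying a primary amine, would give a number in this assay or stop at the limit.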